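The source may report more compounds than this note shows. Statements on the series, on what has been measured and on what is new or still open speak of the compounds shown alone.

Compounds measured so far:

Compound 1, `O=C1C(=O)N(Cc2ccc(-c3cncnc3)cc2)c2ccc(OC(F)(F)F)cc21`, gives 2100 nM in a functional assay on CHO cells for positive allosteric modulation of muscarinic acetylcholine receptor M5 (Homo sapiens), read by FLIPR and calcium flux, with a stated time of 1 h; a lower number here means that less compound is needed, a higher number that more compound is needed for the effect.
Compound 2, `O=C1C(=O)N(Cc2ccc(-c3ccccc3)cc2)c2ccc(OC(F)(F)F)cc21`, gives 1600 nM in this assay.
Compound 3, `O=C1C(=O)N(Cc2ccc(-c3cccnc3)cc2)c2ccc(OC(F)(F)F)cc21`, gives 1600 nM in this assay.

Compound 3 stands level with compound 2 at the digits shown, and the two together sit lowest of the three numbers; the remaining gap is a 1.3-fold lower number from compound 1 to compound 3 (0.12 log units; within the scatter), so all three lie within the usual scatter of one another. The three steps among them, a 1.3-fold lower number from compound 1 to compound 2 (0.12 log units; within the scatter), a 1.3-fold lower number from compound 1 to compound 3 (0.12 log units; within the scatter) and no change at the digits printed from compound 2 to compound 3 (within the scatter), show that exchanging one six-membered aromatic ring for another at this position left the number essentially unchanged.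

Compound 4, `O=C1C(=O)N(Cc2ccc(Oc3nccs3)cc2)c2ccc(OC(F)(F)F)cc21`, has not yet been measured. Its difference from compound 3 is (1,3-thiazol-2-yl)oxy in place of pyridin-3-yl on an aromatic carbon. For the measured compounds named here, none of the measured steps covers this kind of change: every earlier step kept a six-membered ring attached directly to the aromatic carbon, whereas here an oxygen-linked five-membered ring enters. The earlier steps shown here only suggest that this position tolerates variation without large movement in this assay, so the expected outcome is a step of about a 1.3-fold higher number from compound 3 to compound 4 (0.10 log units; within the scatter), that is, no shift clearly beyond the scatter, with wide uncertainty. Compound 4 is therefore estimated at 2000 nM in this assay, within a range from 700 nM to 6000 nM.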

Compound 4, half-maximal effective concentration: 2800 nM
For compound 4 the middle estimate is 1.4-fold (0.15 log units) below the measured one; the range from low to high includes it.
By their numbers in this assay, from the lowest: compounds 2, 3, 1 and 4 (each within the scatter of the next).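

In this assay, the position on the aromatic carbon para to a large group accepts more than a swap among directly attached six-membered rings: with (1,3-thiazol-2-yl)oxy in place of the earlier rings, the steps are a 1.8-fold higher number from compound 3 to compound 4 (0.24 log units; within the scatter), a 1.8-fold higher number from compound 2 to compound 4 (0.24 log units; within the scatter) and a 1.3-fold higher number from compound 1 to compound 4 (0.12 log units; within the scatter). The earlier compounds shown here differed only in the ring nitrogens of a six-membered aromatic ring, whereas compound 4 alters the ring size, brings in oxygen and sulfur, and places an oxygen link at the aromatic carbon, and still none of its steps goes beyond the scatter. No measurement presented here offers an explanation for this tolerance.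

The compounds shown leave open how the oxygen link and the thiazole ring each contribute, as these two parts enter together in compound 4, and a directly attached 1,3-thiazol-2-yl or a phenoxy group would be needed to separate them. They also leave open whether a basic amine, a carboxylic acid or a longer alkyl chain at this position would give a step beyond the scatter in this assay.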